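Swapping a hydroxyphenyl for a nitrophenyl on the core

A few compounds are considered here, and "the series" means these few. Any claim that something is new, unique, unknown or untested is made for them only; others in the source may bear on it.

Of the compounds shown here, three sharing one core have been tested in a functional assay on Ehrlich cells (Mus musculus) for cytotoxicity, read by trypan blue exclusion, with a stated time of 2 h, tested at 10 ug/mL; a higher number here means a stronger effect of the compound at the concentration tested, a lower number a weaker effect. Compound 1 `N#CC1=C(N)N(c2ccc(S(N)(=O)=O)cc2)C2=C(CCCC2)C1c1ccccc1` gives 5%. Compound 2 `N#CC1=C(N)N(c2ccc(S(N)(=O)=O)cc2)C2=C(CCCC2)C1c1ccccc1O`, which carries a hydroxy in place of hydrogen on an aromatic carbon, gives 10%, and the step of a number 5 percentage points higher from compound 1 to compound 2 (within the scatter) stays within the scatter. Compound 3 `N#CC1=C(N)N(c2ccc(S(N)(=O)=O)cc2)C2=C(CCCC2)C1c1ccc(O)cc1` gives 20%, with the step of a number 15 percentage points higher from compound 1 to compound 3 (beyond the scatter) beyond the scatter; the step of a number 10 percentage points higher from compound 2 to compound 3 (within the scatter) is within it. Compound 3 thus sits at the top of the three numbers, but only its gap to compound 1 is clearly beyond the scatter.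

Compound 4 `N#CC1=C(N)N(c2ccc(S(N)(=O)=O)cc2)C2=C(CCCC2)C1c1cccc([N+](=O)[O-])c1` differs from compound 3 by 3-nitrophenyl in place of 4-hydroxyphenyl on a saturated ring carbon. The change removes the hydroxy whose arrival gave the step from compound 1 to compound 3, so that step is the one that bears on it, and it points downward here; the nitrophenyl itself has no precedent among these compounds. Compound 4 is expected to fall back toward the level of compound 1, a step of about a number 10 percentage points lower from compound 3 to compound 4 (within the scatter) in this assay. The estimate for compound 4 is 10%, in a range from 0% to 25%.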

Compound 4, a percentage reported as activity, at one concentration (the size of the read-out at that concentration, not a potency): 0%
The estimate for compound 4 lay 10 percentage points above the measured number; low and high end bracket the measured number.
By their numbers in this assay, from the lowest: compounds 4, 1, 2 and 3 (each within the scatter of the next, the first and the last beyond it).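

Within the data shown here, on this saturated ring carbon, a number 20 percentage points lower from compound 3 to compound 4 (beyond the scatter) in this assay shows that replacing the 4-hydroxyphenyl with the 3-nitrophenyl can lower the read-out by more than the scatter, something no earlier compound could show, as none carried a nitro group. The other two comparisons are less clear: a number 10 percentage points lower from compound 2 to compound 4 (within the scatter) when the 2-hydroxyphenyl is replaced, and a number 5 percentage points lower from compound 1 to compound 4 (within the scatter) when a nitro simply takes the place of a hydrogen, so the nitro group does not separate compound 4 from compound 1 or compound 2. Nothing available explains the difference from compound 3. Still open, as far as these compounds go, is whether the hydroxy itself matters or whether other groups on the phenyl ring would do the same. A 4-aminophenyl or a 4-carboxyphenyl on the same carbon would help settle this.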